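Dichlorophenyl analogue with the cyclopropylpropyl nitrogen substituent

A few compounds are considered here, and "the series" means these few. Any claim that something is new, unique, unknown or untested is made for them only; others in the source may bear on it.

Measured compounds:
compound 1 `CCCC(C)n1c(=O)c(C)nc2c(-c3ccc(Cl)cc3Cl)ccnc21`, 62 nM
compound 2 `Cc1nc2c(-c3ccc(Cl)cc3Cl)ccnc2n(CC(C)C)c1=O`, 3500 nM
compound 3 `CC[C@@H](C1CC1)n1c(=O)c(C)nc2c(-c3ccc(OC(F)F)cc3Cl)ccnc21`, 7.3 nM

In a functional assay for antagonist activity at corticotropin-releasing factor receptor 1 (Rattus norvegicus) (a higher number here means a weaker inhibitor, a lower number a stronger inhibitor), compound 3 gives the lowest number of the three; compound 1 comes nearest, compound 2 furthest, both beyond the scatter. Compound 4 `CC[C@@H](C1CC1)n1c(=O)c(C)nc2c(-c3ccc(Cl)cc3Cl)ccnc21` differs from compound 3 by chloro in place of difluoromethoxy on an aromatic carbon. Within the data shown here, the only measured step, a 56-fold higher number from compound 1 to compound 2 (1.75 log units; beyond the scatter), concerns the substituent on the aromatic nitrogen and is large, but it does not touch the aryl ring and so says nothing about this change. Among the measured compounds shown here, no measured pair shows the difluoromethoxy-to-chloro exchange, and the shared nitrogen substituent of compounds 3 and 4 is untested elsewhere. The step is therefore expected to be small, a 1.6-fold higher number from compound 3 to compound 4 (0.22 log units; within the scatter), and compound 4 is estimated at 12 nM, range 4 nM to 40 nM.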

Compound 4, half-maximal inhibitory concentration: 7.4 nM
Compound 4: middle estimate off by 1.6-fold (0.21 log units), on the high side, and the stated range covers the measured number.
By their numbers in this assay, from the lowest: compounds 3 and 4 (each within the scatter of the next); then compound 1; then compound 2.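

In this assay, with 1-cyclopropylpropyl on the aromatic nitrogen, chloro and difluoromethoxy on this aromatic carbon cannot be told apart (a 1.0-fold higher number from compound 3 to compound 4 (0.01 log units; within the scatter)). The dichlorophenyl compounds now also give a nitrogen comparison: 1-cyclopropylpropyl in place of isobutyl gives a large step (a 470-fold lower number from compound 2 to compound 4 (2.67 log units; beyond the scatter)), and in place of 1-methylbutyl a modest one (an 8.4-fold lower number from compound 1 to compound 4 (0.92 log units; beyond the scatter)). No supporting data are available to explain either the aryl match or the nitrogen steps.

From the compounds shown here alone, whether the chloro and difluoromethoxy match holds with 1-methylbutyl or isobutyl on the nitrogen remains open. Going by these compounds, how a methoxy, nitrile or trifluoromethyl group would read on this aromatic carbon also remains open.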